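Heteroaryl swaps on a shared core: compound 3 to compound 4

The compounds below may be only part of what the source reports. "The series", "measured", "known", "first", "only" and "open" are said of these compounds alone.

Values in a functional assay on CHO-K1 cells for antagonist activity at C-X-C chemokine receptor type 3 (Homo sapiens), read by FLIPR and calcium flux; on this read-out higher numbers stand for weaker inhibition and lower numbers for stronger inhibition:
compound 1 `CC1(C)[C@@H]2CC[C@@]1(CS(=O)(=O)N1CCN(c3cc(C(F)(F)F)ccn3)CC1)C(=O)C2`: 25100 nM
compound 2 `CC1(C)[C@@H]2CC[C@@]1(CS(=O)(=O)N1CCN(c3ccc([N+](=O)[O-])cn3)CC1)C(=O)C2`: > 31600 nM
compound 3 `CC(=O)c1ccc(N2CCN(S(=O)(=O)C[C@]34CC[C@H](CC3=O)C4(C)C)CC2)nc1`: > 31600 nM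

Compound 3 sits at a limit of this assay, > 31600 nM, not at a number. Compound 2 likewise gives only a limit, > 31600 nM. Compound 1 alone yields a number, 25100 nM, itself weak. The measured steps of an at least 1.2-fold higher number from compound 1 to compound 2 (0.10 log units; that floor lies within the scatter) and an at least 1.2-fold higher number from compound 1 to compound 3 (0.10 log units; that floor lies within the scatter) are both floors, and a step that the two limits leave unreadable from compound 2 to compound 3 cannot be sized at all, because of the limit of > 31600 nM in this assay, at which 2 of the 3 values shown sit.

Compound 4 `CC1(C)[C@@H]2CC[C@@]1(CS(=O)(=O)N1CCN(c3ncc(Br)cn3)CC1)C(=O)C2` differs from compound 3 by 5-bromopyrimidin-2-yl in place of 5-acetylpyridin-2-yl on an amine nitrogen in a ring. Two of the three heteroaryl variants already sit at the limit and the third is close to it, so for compound 4 a step of a number no higher from compound 3 to compound 4 (the limit leaves the size open) is expected in this assay, none beyond the scatter, with a fair chance that only a limit is reported again. Compound 4 is therefore estimated at 31600 nM, within 12000 nM to 80000 nM.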

Compound 4, half-maximal inhibitory concentration: 631 nM
For compound 4 the middle estimate is 50-fold (1.70 log units) above the measured one; measured number outside the range, below it.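

On the shared core, the group on the amine nitrogen in a ring can carry real activity in this assay, which compound 1, compound 2 and compound 3 did not show. With 5-bromopyrimidin-2-yl at this position the steps are an at least 50-fold lower number from compound 3 to compound 4 (1.69 log units; beyond the scatter), an at least 50-fold lower number from compound 2 to compound 4 (1.69 log units; beyond the scatter) and a 40-fold lower number from compound 1 to compound 4 (1.60 log units; beyond the scatter), all beyond the scatter, so compound 4 is the most potent of the four. The first two steps are floors, and the step between compound 2 and compound 3 cannot be read, both because of this limit: the limit of > 31600 nM in this assay, at which 2 of the 4 values shown sit.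

The entering group changes the ring hetero atoms and the substituent at once, so the shift cannot be assigned to the extra ring nitrogen or to the bromine; 5-bromopyridin-2-yl and unsubstituted pyrimidin-2-yl would separate the two. Also open, as far as these compounds go, is whether chlorine or methyl in place of the bromine keeps this activity.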